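The compounds below may be only part of what the source reports. "The series", "measured", "known", "first", "only" and "open" are said of these compounds alone.

Measured compounds: compound 1 `CCCCC#Cc1ccc(S(=O)(=O)Nc2cccc(-c3csc(NC(C)=O)n3)c2)cc1`, which in a functional assay on A-375 cells (Homo sapiens) for antiproliferative activity, read by trypan blue exclusion, with a stated time of 48 h, tested at 10 uM (a lower number here means a stronger effect, a higher number a weaker effect of the compound at the concentration tested), gives < 1%, a limit of the assay rather than a number. Compound 2 `CCCCCCC#Cc1cccc(S(=O)(=O)Nc2cccc(-c3csc(NC(C)=O)n3)c2)c1` gives < 1%, likewise a limit. Compound 3 `CC(=O)Nc1nc(-c2cccc(NS(=O)(=O)c3cccc(C#CCO)c3)c2)cs1` gives 45.3%.

Compound 1 thus stands at the floor of the numbers shown, the limit described by the limit of < 1% in this assay, at which 2 of the 3 values shown sit. Going by the values given here, the one measured step, a number at least 44.3 percentage points higher from compound 2 to compound 3 (beyond the scatter), is large, but it concerns a hydroxy in place of pentyl and does not touch the change now considered. Compound 4 `CCCCCCc1ccc(S(=O)(=O)Nc2cccc(-c3csc(NC(C)=O)n3)c2)cc1` differs from compound 1 by hexyl in place of hex-1-yn-1-yl on an aromatic carbon. Among the compounds with values here, no measured step bears on hexyl in place of hex-1-yn-1-yl, so the expected step is a number at least 5 percentage points higher from compound 1 to compound 4 (that floor lies within the scatter), small and within the scatter. Compound 4 is therefore estimated at 6%, between 0% and 25%, quite possibly again reported only as a limit.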

Compound 4, a percentage reported as activity, at one concentration (the size of the read-out at that concentration, not a potency): <= 1%
Compound 4: only a limit was reported; the forecaster's own chance of this, stated with the estimate: 50%; at least 5 percentage points between middle value and limit.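

Compound 1 and compound 4 are each reported only as a limit in this assay, and the step between them cannot be read. The compounds shown leave open whether hexyl and hex-1-yn-1-yl differ at all in effect.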